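Replacing furan-2-yl with 1H-pyrazol-1-yl

This account rests on a few compounds, and the source may have more. Where it says the series, first, only, none or still open, it means among the compounds named here.

- compound 1 `NC1CCC(Nc2nc(NCc3ccc(-c4cccc(F)c4)cc3)c3ncn(C4CCCC4)c3n2)CC1`: 290 nM
- compound 2 `NC1CCC(Nc2nc(NCc3ccc(-c4ccco4)cc3)c3ncn(C4CCCC4)c3n2)CC1`: 96 nM

All values come from a functional assay on K562 cells (Homo sapiens) for inhibition, with a stated time of 72 h; on this read-out higher numbers stand for weaker inhibition and lower numbers for stronger inhibition. Of the two numbers, compound 2 holds the lower, at 96 nM. Compound 3 `NC1CCC(Nc2nc(NCc3ccc(-n4cccn4)cc3)c3ncn(C4CCCC4)c3n2)CC1` has 1H-pyrazol-1-yl in place of furan-2-yl on an aromatic carbon. Among the compounds with values here, the only measured step at this place is a 3.0-fold lower number from compound 1 to compound 2 (0.48 log units; beyond the scatter), a modest change that introduced furan-2-yl in place of 3-fluorophenyl. It offers no direct reading on a swap between two five-membered aromatic rings, so no change beyond the scatter is expected in this assay. The expected step is a 1.3-fold higher number from compound 2 to compound 3 (0.10 log units; within the scatter). For compound 3, the estimate is 120 nM, with an expected range of 50 nM to 300 nM.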

Compound 3, half-maximal inhibitory concentration: 119 nM
For compound 3 the middle estimate is 1.0-fold (0.00 log units) above the measured one; low and high end bracket the measured number.
By their numbers in this assay, from the lowest: compounds 2 and 3 (each within the scatter of the next); then compound 1.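

In this assay, the 4-substituent on the phenyl accepts a second five-membered aromatic ring: there is a 1.2-fold higher number from compound 2 to compound 3 (0.09 log units; within the scatter) even though 1H-pyrazol-1-yl has two ring hetero atoms and furan-2-yl has one. The comparison with 3-fluorophenyl also holds for this second ring, with a 2.4-fold lower number from compound 1 to compound 3 (0.39 log units; beyond the scatter) from the same place. The compounds shown leave open whether a morpholine, a primary amine or a carboxylic acid on this aromatic carbon would keep the number near those of compound 2 and compound 3. No measured evidence bears on what lies behind these readings.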